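A few compounds are considered here, and "the series" means these few. Any claim that something is new, unique, unknown or untested is made for them only; others in the source may bear on it.

Three compounds share a di-iodinated hydroxyphenyl unit joined through a hydrazide linkage to a second aromatic ring. Compound 1 `Cc1ccc(C(=O)N/N=C/c2cc(I)cc(I)c2O)cc1` carries a methyl group on that second ring; compound 2 `O=C(N/N=C/c1cc(I)cc(I)c1O)c1ccc(Cl)cc1` carries a chloro group instead; compound 3 `O=C(NNC(=O)c1cc(I)cc(I)c1O)c1ccccc1` has the second ring unsubstituted and a second carbonyl in the linker. All three were tested in a functional assay on HepG2 cells (Homo sapiens) for cytotoxicity, with a stated time of 24 h; on this read-out higher numbers stand for weaker inhibition and lower numbers for stronger inhibition. For compound 1 this assay reports only a limit, > 25000 nM, and not a number. Compound 2 gives 14800 nM. Compound 3 gives 98000 nM, the higher of the two numbers shown. Within the data shown here, the one measured step, an at least 1.6-fold lower number from compound 1 to compound 2 (0.22 log units; that floor lies within the scatter), reflects a methyl replaced by a chloro, and its floor rests on the limit described in the limit of > 25000 nM in this assay, at which 1 of the 3 values shown sits.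

Compound 4 `O=C(NNC(=O)c1cc(I)cc(I)c1O)c1ccc(C(F)(F)F)cc1` differs from compound 3 by one change: trifluoromethyl in place of hydrogen on an aromatic carbon. Among the measured compounds shown here, no measured step involves a trifluoromethyl group or the core of compound 3, so the step from compound 1 to compound 2 bears only loosely on it, and it was itself small. Compound 4 is therefore expected to give around 80000 nM, in a range from 30000 nM to 200000 nM. That estimate corresponds to a 1.2-fold lower number from compound 3 to compound 4 (0.09 log units; within the scatter), a step expected to stay within the scatter.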

Compound 4, half-maximal inhibitory concentration: 167000 nM
Compound 4: the middle estimate sits 2.1-fold (0.32 log units) below what was measured, and the stated range covers the measured number.
By their numbers in this assay, from the lowest: compound 2; then compounds 3 and 4 (each within the scatter of the next).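

On the second ring of compound 3, trifluoromethyl in place of hydrogen on an aromatic carbon, para to a large group, gives a 1.7-fold higher number from compound 3 to compound 4 (0.23 log units; within the scatter) in this assay, so a group of 4 heavy atoms at this position leaves the result inside the scatter. Among these compounds, this is the first step in the set with a measured number at both ends, and the first on the core that has the second carbonyl in the linker, so a substituent on that ring can now be read directly on this core. Compound 1 stands at a limit and not a number, so the only earlier step gave just a floor: the limit of > 25000 nM in this assay, at which 1 of the 4 values shown sits.

The compounds shown leave open whether this position would stay as undemanding with an amine, a carboxylic acid or a longer carbon chain in place of trifluoromethyl, since one group on one core is all that can be read here. They also leave open whether chloro or methyl on the core of compound 3 would give a step like the one seen on the core of compound 1, and whether trifluoromethyl would give the same result on that other core.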